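A few compounds are considered here, and "the series" means these few. Any claim that something is new, unique, unknown or untested is made for them only; others in the source may bear on it.

Compound 1 has the structure `CC(C)N(Cc1cccc(OCCCCCC(=O)O)c1)C(=O)c1ccc(-c2ccoc2)cc1`. In an ADME assay on HepG2 cells (Homo sapiens) for cytotoxicity, read by CellTiter-Glo and resazurin assay, with a stated time of 72 h (on this read-out lower numbers stand for an effect already at smaller amounts and higher numbers for an effect only at larger amounts of compound), compound 1 gives > 26000 nM, which is a limit of the assay and not a number. Compound 2 has the structure `COc1cccc(-c2ccc(C(=O)N(Cc3cccc(OCCCCCC(=O)O)c3)C(C)C)cc2)c1`. In this assay compound 2 gives > 26000 nM, again a limit rather than a number.

Going by the values given here, compound 2 therefore stands only at a limit in this assay, as does the single other value shown: both sit at the limit of > 26000 nM in this assay, at which 2 of the 2 values shown sit. Among the compounds with values here, the one measured step, a step that the two limits leave unreadable from compound 1 to compound 2, is consequently unreadable in size; the two limits say only that neither compound showed an effect within the tested range.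

Compound 3, the unmeasured compound, has the structure `COc1cc(OC)cc(-c2ccc(C(=O)N(Cc3cccc(OCCCCCC(=O)O)c3)C(C)C)cc2)c1`. It differs from compound 2 by methoxy in place of hydrogen on an aromatic carbon. Within the data shown here, no measured step bears directly on this change, and the single step that exists cannot be read in size. The expectation for the step that the limit leaves unreadable from compound 2 to compound 3 in this assay is therefore none beyond the scatter, with a further limit being the most likely outcome. On that basis compound 3 is estimated at 40000 nM, within 15000 nM to 120000 nM.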

Compound 3, half-maximal effective concentration: > 26000 nM
Compound 3: only a limit was reported; the forecaster's own chance of this, stated with the estimate: 85%; the middle value is on the limit's open side.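

In this assay compound 3 gives > 26000 nM, which is a limit of the assay and not a number, so its steps from compound 1 and compound 2 cannot be read in size. Compound 1, compound 2 and compound 3 leave open whether furan-3-yl, 3-methoxyphenyl or 3,5-dimethoxyphenyl changes the half-maximal effective concentration at all, because all three values stand at one limit: the limit of > 26000 nM in this assay, at which 3 of the 3 values shown sit.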